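The source may report more compounds than this note shows. Statements on the series, on what has been measured and on what is new or still open speak of the compounds shown alone.

Measured so far in a physicochemical assay for lipophilicity; a higher number here means a more lipophilic compound, a lower number a more polar compound:

compound 1 `CCCCN(C)/N=N/c1ccc(C(=O)O)cc1` gives 0.97
compound 2 `CCCCCCN(C)/N=N/c1ccc(C(=O)O)cc1` gives 1.95
compound 3 `C=CCN(C)/N=N/c1ccc(C(=O)O)cc1` gives 0.32

Compound 1 stands second highest of the three numbers in this assay. Its nearest neighbour is compound 3, the step of a number 0.65 log units lower from compound 1 to compound 3 (beyond the scatter); the furthest is compound 2, the step of a number 0.98 log units higher from compound 1 to compound 2 (beyond the scatter). The chain on the amine nitrogen is the only thing that varies across the series, and each change so far has moved this assay beyond the scatter.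

Compound 4 `C#CCN(C)/N=N/c1ccc(C(=O)O)cc1` is not yet measured. Against compound 1 the change is ethynyl in place of propyl on a saturated chain carbon bound to an amine nitrogen. Within the data shown here, two measured steps bear on it. The step of a number 0.65 log units lower from compound 1 to compound 3 (beyond the scatter) is the closest parallel: there too a shorter unsaturated group replaced propyl on the same carbon, and the number fell by a modest amount. The step of a number 1.63 log units lower from compound 2 to compound 3 (beyond the scatter) shows the same direction from a longer chain, with a large fall. Ethynyl carries one carbon fewer than vinyl, so a drop at least as large as that from compound 1 to compound 3 is expected, in the downward direction, beyond the scatter.

The expected step is a number 0.87 log units lower from compound 1 to compound 4 (beyond the scatter). Compound 4 is therefore estimated at 0.1, with a range from -0.4 to 0.6.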

Compound 4, partition coefficient: 0
Compound 4: the middle estimate sits 0.10 log units above what was measured; the range from low to high includes it.
By their numbers in this assay, from the lowest: compound 4; then compound 3; then compound 1; then compound 2.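

In this assay the ethynyl group takes the series to its lowest number: a number 0.97 log units lower from compound 1 to compound 4 (beyond the scatter), and over the full span of chains tested, a number 1.95 log units lower from compound 2 to compound 4 (beyond the scatter). New here is that this position also separates two unsaturated groups of similar kind, since a number 0.32 log units lower from compound 3 to compound 4 (beyond the scatter), whereas the earlier steps only set vinyl against saturated chains. On the saturated chain carbon bound to an amine nitrogen, the four groups now fall in one order, from pentyl through propyl and vinyl to ethynyl, and no compound shown goes against it. No other data bearing on these steps are available.

Still open is whether a cyclopropyl ring, a hydroxyl or an amine at this place would fit the same order, as every chain shown here consists of carbon and hydrogen alone. Also open, as far as these compounds go, is whether the steps would keep their size with an amide in place of the carboxylic acid on the shared core.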